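Trimming a Benzamide Tail in a Pyrazole Series

The source may hold more compounds than are shown below. What is called first, only, known or untested is meant among the compounds shown, and "the series" means these compounds.

Going by the values given here, compound 3 `COc1cc(-c2nn(-c3cccc(NC(=O)c4ccc(Cl)c(C(F)(F)F)c4)c3)cc2-c2ccncc2)ccc1Cl` stands second highest among the three numbers so far in a functional assay on NCI-H522 cells (Homo sapiens) for inhibition, read by sulforhodamine B assay, with a stated time of 48 h (on this read-out lower numbers stand for stronger inhibition of growth and higher numbers for weaker inhibition of growth), where compound 3 gives 1040 nM; compound 1 `O=C(Nc1cccc(-n2cc(-c3ccncc3)c(-c3ccc(Cl)c(O)c3)n2)c1)Nc1cccc(C(F)(F)F)c1` gives 1460 nM and compound 2 `COc1cc(-c2nn(-c3cccc(NC(=O)Nc4cccc(C(F)(F)F)c4)c3)cc2-c2ccncc2)ccc1Cl` gives 714 nM. Compound 4 `COc1cc(-c2nn(-c3cccc(NC(=O)c4ccccc4)c3)cc2-c2ccncc2)ccc1Cl` differs from compound 3 by phenyl in place of 4-chloro-3-(trifluoromethyl)phenyl on a carbonyl carbon. Among the compounds with values here, no measured step touches this position alone. The nearest step, a 1.5-fold higher number from compound 2 to compound 3 (0.16 log units; within the scatter), swapped the whole amide-side group, while a 2.0-fold lower number from compound 1 to compound 2 (0.31 log units; beyond the scatter) concerned an oxygen on an aromatic ring. Neither shows how removing chloro and trifluoromethyl will act, so the expected step, a 1.4-fold higher number from compound 3 to compound 4 (0.16 log units; within the scatter), is small and uncertain, with a slight lean toward a higher number. Compound 4 is therefore estimated at 1500 nM, within a range of 600 nM to 4000 nM.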

Compound 4, concentration for 50% growth inhibition: 317 nM
For compound 4 the middle estimate is 4.7-fold (0.68 log units) above the measured one, outside the stated range (below it).
By their numbers in this assay, from the lowest: compound 4; then compounds 2, 3 and 1 (each within the scatter of the next, the first and the last beyond it).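

In this assay, going by these compounds alone, stripping both chloro and trifluoromethyl from the phenyl on this carbonyl carbon gives a 3.3-fold lower number from compound 3 to compound 4 (0.52 log units; beyond the scatter) and so strengthens growth inhibition beyond the scatter, which the earlier compounds did not show. The bare phenyl also improves on the (3-(trifluoromethyl)phenyl)amino group, with a 2.3-fold lower number from compound 2 to compound 4 (0.35 log units; beyond the scatter) in the same direction. Nothing available explains why the simpler group does better. Chloro and trifluoromethyl leave together here, so the share of each remains open. From the compounds shown here alone, how a phenyl carrying an amine or a carboxylic acid would behave also remains open.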